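The compounds below may be only part of what the source reports. "The series", "measured", "known", "first", "only" and "open" are said of these compounds alone.

Measured compounds:
compound 1 `COc1ccc(C(=O)c2cc(OC)c(OC)c(OC)c2)cc1NC(=O)/C=C/c1ccc(F)cc1`: 300 nM in a functional assay on ME-180 cells (Homo sapiens) for cytotoxicity, read by MTT assay, with a stated time of 72 h; on this read-out lower numbers stand for stronger inhibition and higher numbers for weaker inhibition
compound 2 `COc1cc(/C=C/C(=O)Nc2cc(C(=O)c3cc(OC)c(OC)c(OC)c3)ccc2OC)ccc1F`: 15500 nM

Within the data shown here, compound 2 gives the highest of the two numbers in this assay; the only neighbour is compound 1, and the step of a 52-fold higher number from compound 1 to compound 2 (1.71 log units; beyond the scatter) separates them.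

Compound 3 `COc1ccc(C(=O)c2cc(OC)c(OC)c(OC)c2)cc1NC(=O)/C=C/c1ccc(F)c(F)c1` carries the change (fluoro in place of methoxy on an aromatic carbon). Among the measured compounds shown here, no measured step puts fluoro in place of methoxy; the step of a 52-fold higher number from compound 1 to compound 2 (1.71 log units; beyond the scatter), in which methoxy enters at this same carbon, is the one that bears on it. Taking fluoro as a small substituent standing nearer to hydrogen than to methoxy, a large drop in this assay is expected, with the step estimated as a 31-fold lower number from compound 2 to compound 3 (1.49 log units; beyond the scatter). Compound 3 is therefore expected at 500 nM, within 150 nM to 2000 nM.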

Compound 3, half-maximal inhibitory concentration: 8900 nM
The estimate for compound 3 lay 18-fold (1.25 log units) below the measured number; measured number above the stated range.
By their numbers in this assay, from the lowest: compound 1; then compounds 3 and 2 (each within the scatter of the next).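

Fluoro at the carbon ortho to a fluoro group does not recover what methoxy loses there: a 30-fold higher number from compound 1 to compound 3 (1.47 log units; beyond the scatter) is large, whereas a 1.7-fold lower number from compound 2 to compound 3 (0.24 log units; within the scatter) separates the 4-fluoro-3-methoxyphenyl and 3,4-difluorophenyl compounds by no more than the usual scatter. The loss is therefore not confined to methoxy, and of the three compounds only compound 1, with hydrogen at this carbon, stands apart. Nothing measured here accounts for this loss.

As far as these compounds go, whether any substituent at this carbon can match hydrogen remains open. Among these compounds, a hydroxyl group, an amine or a chloro group would test that, and the series so far covers only fluoro and methoxy.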